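The source may hold more compounds than are shown below. What is called first, only, known or untested is meant among the compounds shown, and "the series" means these compounds.

Measured compounds:
- compound 1, `CCCN(CCC)S(=O)(=O)c1ccc(S(=O)(=O)N2CCC[C@@H](C(=O)OCC)C2)cc1`: 2300 nM
- compound 2, `CCOC(=O)[C@@H]1CCCN(S(=O)(=O)c2cccc(S(=O)(=O)N(CC)CC)c2)C1`: > 30000 nM
- compound 3, `CCN(CC)S(=O)(=O)c1ccc(S(=O)(=O)N2CCC[C@@H](C(=O)N3CCN(c4nc(C)no4)CC3)C2)cc1`: 250 nM

In a functional assay on MIA PaCa-2 cells (Homo sapiens) for inhibition, read by MTT assay, with a stated time of 7 days (a higher number here means a weaker inhibitor, a lower number a stronger inhibitor), compound 1 gives 2300 nM. Compound 3 gives 250 nM in this assay, and the gap between the two numbers lies beyond the usual scatter, so compound 1 stands with the higher of the two numbers. For compound 2 this assay reports only a limit, (the limit of > 30000 nM in this assay, at which 1 of the 3 values shown sits), and not a number.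

Compound 4, `CCOC(=O)[C@@H]1CCCN(S(=O)(=O)c2ccc(S(=N)(=O)N(CC)CC)cc2)C1`, has not yet been measured in this assay. It is reached from compound 1 by one change: a group of 8 heavy atoms (4 carbon, 2 nitrogen, 1 oxygen, 1 sulfur; no ring) in place of a group of 10 heavy atoms (6 carbon, 1 nitrogen, 2 oxygen, 1 sulfur; no ring), on an aromatic carbon. For the measured compounds named here, no step between measured compounds shows this change, so there is nothing to lean on beyond the structures themselves. The expectation is a step from compound 1 to compound 4 of a 1.3-fold higher number from compound 1 to compound 4 (0.12 log units; within the scatter), which stays within the scatter of repeated measurements, in no clear direction. On that basis compound 4 is estimated at 3000 nM in this assay, with a range from 800 nM to 12000 nM.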

Compound 4, half-maximal inhibitory concentration: 2600 nM
Compound 4: middle estimate off by 1.2-fold (0.06 log units), on the high side; the measured number falls inside the stated range.
By their numbers in this assay, from the lowest: compound 3; then compounds 1 and 4 (each within the scatter of the next). At a limit, above all of these: compound 2.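

Within this assay the exchange of dipropylsulfamoyl for a group that, unlike it, holds a hydrogen-bond donor shows a 1.1-fold higher number from compound 1 to compound 4 (0.05 log units; within the scatter) and so the two compounds cannot be told apart. On this aromatic carbon, para to a large group, the two groups therefore leave the number in the same place, even though they differ in size and in their atoms. For the compounds shown here, no earlier pair differed in one place alone, so this is the only direct reading of this position.

Nothing measured here says why the two groups read alike. Still open, on these data alone, is whether an amine, a carboxylic acid or a chain longer than propyl on the sulfamoyl nitrogen would read the same at this place, and whether the same exchange would read alike on the core of compound 3.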